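Halogen swap on the shared core: compound 3 to compound 4

This account rests on a few compounds, and the source may have more. Where it says the series, first, only, none or still open, it means among the compounds named here.

Compound 3 `O=c1c(-c2nn[nH]n2)c[nH]c2c(Br)cccc12` carries a bromo group on the six-membered carbon ring of the shared core. In a functional assay on the whole organism (strain Sprague-Dawley) for inhibition, with Rattus norvegicus as the target (a higher number here means that more compound is needed for the effect, a lower number that less compound is needed), compound 3 reaches only a limit, > 10 mg/kg, so no number stands for it. Compound 2 `COc1ccc2ncc(-c3nn[nH]n3)cc2c1`, built on a different core, also gives only a limit in this assay, > 25 mg/kg. Within the data shown here, the one compound with a number is compound 1 `O=c1c(-c2nn[nH]n2)c[nH]c2c(F)ccc(F)c12`, which carries two fluoro groups on the same core; in this assay compound 1 gives 10 mg/kg.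

Compound 4 `O=c1c(-c2nn[nH]n2)c[nH]c2c(F)cccc12` differs from compound 3 by fluoro in place of bromo on an aromatic carbon. No measured step between any two of these compounds exists, so the move from compound 3 to compound 4 rests on compound 1, whose fluoro-bearing core gives 10 mg/kg. It also rests on compound 3, which sits at the limit of > 10 mg/kg in this assay, at which 1 of the 3 values shown sits. The step from compound 3 to compound 4 is expected to run toward a lower dose, a number no higher from compound 3 to compound 4 (the limit leaves the size open), with its size uncertain since compound 3 starts at a limit. Compound 4 is estimated at 10 mg/kg, within a range of 5 mg/kg to 25 mg/kg.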

Compound 4, minimum effective dose: 10 mg/kg
Estimate against measurement, compound 4: no gap at the digits printed; the measured number falls inside the stated range.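

In this assay, among these compounds, fluoro in place of bromo on this aromatic carbon gives the first step on the shared core that involves a single halogen, and it reads as a number no higher from compound 3 to compound 4 (the limit leaves the size open). Compound 3 stands only at a limit: the limit of > 10 mg/kg in this assay, at which 1 of the 4 values shown sits. The further fluoro group of compound 1 makes no readable difference, as hydrogen in its place gives no change at the digits printed from compound 1 to compound 4 (within the scatter), so a single fluoro group on the shared core is enough to match the number of compound 1 in this assay.

The size of the step from bromo to fluoro stays unknown, and the shared core is shown here with halogens only. Going by these compounds, whether a nitrile, a methyl group or an amine on this aromatic carbon would hold the dose of compound 4 remains open.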